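The compounds below may be only part of what the source reports. "The series", "measured", "known", "first", "only" and "open" are said of these compounds alone.

Compound 1 `COc1ccc(-c2cc3nccc(-c4cc(OC)c(OC)c(OC)c4)n3n2)cc1N` gives 27 nM in a functional assay on MCF7 cells (Homo sapiens) for inhibition, read by CCK-8 assay, with a stated time of 48 h (on this read-out lower numbers stand for stronger inhibition and higher numbers for weaker inhibition), the lowest of the two numbers in hand. Compound 2 `COc1cc(-c2ccnc3cc(-c4ccccc4)nn23)cc(OC)c1OC` gives 254 nM in this assay, and the step of a 9.4-fold higher number from compound 1 to compound 2 (0.97 log units; beyond the scatter) follows from removing the 3-amino-4-methoxyphenyl group. Compound 3 `COc1cc(-c2ccnc3cc(-c4cccc(C#N)c4)nn23)cc(OC)c1OC` carries the change (3-cyanophenyl in place of 3-amino-4-methoxyphenyl on an aromatic carbon). Going by the values given here, the only step that bears on it is the one from compound 1 to compound 2, so a weakening of similar but perhaps somewhat smaller size is expected. For compound 3 the estimate is 150 nM, between 50 nM and 500 nM, amounting to an expected step of a 5.6-fold higher number from compound 1 to compound 3 (0.74 log units; beyond the scatter).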

Compound 3, half-maximal inhibitory concentration: > 10000 nM
Compound 3 was reported as a limit; the forecaster's own chance of this, stated with the estimate: 3%; middle value at least 66-fold (1.82 log units) away from the limit.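

The loss is far greater than compound 2 suggested, as 3-cyanophenyl gives an at least 370-fold higher number from compound 1 to compound 3 (2.56 log units; beyond the scatter). Putting cyano in place of hydrogen on the phenyl ring alone gives an at least 39-fold higher number from compound 2 to compound 3 (1.59 log units; beyond the scatter), so one added group on this ring can cost more than losing the amino and methoxy groups together. Compound 3 is reported only as a limit, so both steps are bounds: the limit of > 10000 nM in this assay, at which 1 of the 3 values shown sits.

Which of the amine and the methoxy group in compound 1 accounts for its value stays open. So does what a primary amide or a hydroxyl in place of the nitrile would give.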